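Methyl branching on the chain across two cores

This account rests on a few compounds, and the source may have more. Where it says the series, first, only, none or still open, it means among the compounds named here.

Compound 1 `N=C(S)CCn1ncccc1=S` and compound 3 `C/N=C(\S)CCn1ncccc1=O` rest on different cores; the difference between the two cores is not broken down here. In a functional assay on the whole organism (stomach) for inhibition, with Rattus norvegicus as the target, at a dose of 100 mg/kg by the intraduodenal route (a higher number here means more inhibition at the dose given (going by the name of the read-out), a lower number less inhibition), compound 1 gives 50%, while compound 3 gives 35.7%. Compound 2 `C/N=C(\S)C(C)Cn1ncccc1=O` differs from compound 3 by methyl in place of hydrogen on a saturated chain carbon bound to a carbon with a double bond to nitrogen and a saturated chain carbon, and in this assay compound 2 gives 50.2%, a step of a number 14.5 percentage points higher from compound 3 to compound 2 (beyond the scatter). Compound 1 and compound 2 lie within the scatter of each other.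

Compound 4 `CC(Cn1ncccc1=S)C(=N)S` is not yet measured. It differs from compound 1 by methyl in place of hydrogen on a saturated chain carbon bound to a carbon with a double bond to nitrogen and a saturated chain carbon, the same change as the one seen on the other core. Among the measured compounds shown here, the step from compound 1 to compound 4 is expected to be a number 10 percentage points higher from compound 1 to compound 4 (within the scatter) because a number 14.5 percentage points higher from compound 3 to compound 2 (beyond the scatter) is the only measured instance of this change, on one core only. Compound 4 is thus estimated at 60% in this assay, between 45% and 75%.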

Compound 4, a percentage reported as inhibition, in the whole organism at one dose (the size of the read-out at that dose, not a potency): -1%
For compound 4 the middle estimate is 61 percentage points above the measured one, outside the stated range (below it).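

Methyl in place of hydrogen on this saturated chain carbon does not carry from one core to the other in this assay, where the new step reads a number 51 percentage points lower from compound 1 to compound 4 (beyond the scatter) and the two steps run in opposite directions: the same change on two cores in this assay, a number 14.5 percentage points higher (beyond the scatter) from compound 3 to compound 2 and a number 51 percentage points lower (beyond the scatter) from compound 1 to compound 4, 65.5 percentage points apart, beyond the scatter of two such steps

Among the compounds shown here, the outcome of this change therefore depends on the core in these two pairs, though each core offers only a single instance at a single dose. The result does not show which difference between the cores decides the direction.

Open, from the compounds shown here alone, is whether ethyl in place of methyl at this carbon would follow the same split. Also open, going by these compounds, is which way the step would run on a core differing from either core in only one place.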